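Series notes: from nitro compound 3 to bromo compound 4

The source may report more compounds than this note shows. Statements on the series, on what has been measured and on what is new or still open speak of the compounds shown alone.

Values in a functional assay on cells (Erythrocyte, Rattus norvegicus) for inhibition, read by hemolysis, with a stated time of 1 h (a lower number here means a stronger inhibitor, a higher number a weaker inhibitor), so far
Compound 1 `COc1cc(OC)c(OC)cc1/C=C/C(=O)c1ccc(O)cc1O` gives 2.37 ug/mL
Compound 2 `COc1cc(OC)c(OC)cc1/C=C/C(=O)c1ccc(O)cc1` gives 2.29 ug/mL
Compound 3 `COc1cc(OC)c(OC)cc1/C=C/C(=O)c1ccc([N+](=O)[O-])cc1` gives 2.34 ug/mL

Compound 3 at 2.34 ug/mL stands level with the other two compounds. Each gap lies within the scatter, so no order can be read among the three. Compound 4 `COc1cc(OC)c(OC)cc1/C=C/C(=O)c1ccc(Br)cc1` carries bromo in place of nitro on an aromatic carbon, para to a large group (bromo in place of nitro on an aromatic carbon).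

For the measured compounds named here, two measured steps bear on this change. Nitro in place of hydroxy gave (a 1.0-fold higher number from compound 2 to compound 3 (0.01 log units; within the scatter)) and hydrogen in place of hydroxy gave (a 1.0-fold lower number from compound 1 to compound 2 (0.01 log units; within the scatter)), both within the scatter. Going by the values given here, no bromo compound has been measured, so the expectation rests on these three compounds alone. In this assay no step beyond the scatter is expected, and no direction is favoured, the expected move being (a 1.0-fold higher number from compound 3 to compound 4 (0.01 log units; within the scatter)) in size. For compound 4 the estimate is 2.4 ug/mL within an expected range of 1.4 ug/mL to 4 ug/mL on present evidence.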

Compound 4, half-maximal inhibitory concentration: 2.3 ug/mL
Compound 4: middle estimate off by 1.0-fold (0.02 log units), on the high side; the range from low to high includes it.
By their numbers in this assay, from the lowest: compounds 2, 4, 3 and 1 (each within the scatter of the next).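

In this assay, bromo in place of nitro on an aromatic carbon, para to a large group (a 1.0-fold lower number from compound 3 to compound 4 (0.01 log units; within the scatter)), swaps a group carrying hydrogen-bond acceptors for one carrying none, and the number stays within the scatter. The first halogen in the series also stays level with the hydroxy compound (a 1.0-fold higher number from compound 2 to compound 4 (0.00 log units; within the scatter)) and with the 2,4-dihydroxyphenyl compound (a 1.0-fold lower number from compound 1 to compound 4 (0.01 log units; within the scatter)), so hydroxy, hydrogen, nitro and bromo at this position give no readable order in this assay. No accompanying measurement offers an account of this flat result.

On these data alone, whether an amine, a carboxylic acid or a longer chain such as butyl on this ring would move the number remains open. Also open, as far as these compounds go, is whether any change to the shared core outside this position would shift the number beyond the scatter.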